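The source may hold more compounds than are shown below. What is called first, only, known or untested is meant among the compounds shown, and "the series" means these compounds.

Working notes on a three-compound set in a functional assay on Bel-7402 cells (Homo sapiens) for inhibition, read by MTT assay, with a stated time of 24 h, tested at 100 ug/mL; on this read-out lower numbers stand for less inhibition of growth and higher numbers for more inhibition of growth at the one concentration tested. Compound 3 `O=C(CCCCC(S)CCS)Nc1ccc(F)cc1` gives 11.7%, the lowest of the three numbers and beyond the scatter from both of the others. Compound 1 `O=C(CCCCC1CCSS1)Nc1ccc([N+](=O)[O-])c(C(F)(F)F)c1`, which also bears a nitro but differs elsewhere, gives 23.9%, and compound 2 `O=C(CCCCC1CCSS1)Nc1ccc(Br)cn1` gives 45.5%. Compound 4 `O=C(CCCCC(S)CCS)Nc1ccc([N+](=O)[O-])cc1` changes one group of compound 3: nitro in place of fluoro on an aromatic carbon, para to a large group (nitro in place of fluoro on an aromatic carbon). No measured pair isolates this change, so its size is not shown directly. A small upward move in this assay, within the scatter, is expected, and the estimated change is a number 6.3 percentage points higher from compound 3 to compound 4 (within the scatter). For compound 4 the expected value is 18%, with an estimated range of 7% to 33%.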

Compound 4, percent growth inhibition at one concentration: 33.4%
Compound 4: the middle estimate sits 15.4 percentage points below what was measured; measured number outside the range, above it.
By their numbers in this assay, from the lowest: compound 3; then compounds 1 and 4 (each within the scatter of the next); then compound 2.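

In this assay the series now has its first pair differing in one place, and it gives a number 21.7 percentage points higher from compound 3 to compound 4 (beyond the scatter) for nitro in place of fluoro on an aromatic carbon, para to a large group. This position therefore responds to the choice of group, at least on the core of compound 3. Nothing measured here accounts for the step.

Still open, as far as these compounds go, is what an amine or a carboxylic acid at this position would give. The compounds shown also leave open whether the same change produces a similar step on the core of compound 1.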